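Aryl swap on the shared core: compound 3 to compound 4

This account rests on a few compounds, and the source may have more. Where it says the series, first, only, none or still open, it means among the compounds named here.

Measured in a functional assay on MCF7 cells (Homo sapiens) for antiproliferative activity, read by MTT assay, with a stated time of 72 h; a lower number here means a stronger inhibitor, a higher number a weaker inhibitor:
- compound 1 `CC1=CC[C@H]2[C@H](CC[C@]2(C)O)C(C)(C)[C@@H]1CC[C@H]1[C@]2(C)CC[C@H](OC(=O)c3ccncc3)C(C)(C)O[C@H]2CC[C@@]1(C)O`: 25300 nM
- compound 2 `CC1=CC[C@H]2[C@H](CC[C@]2(C)O)C(C)(C)[C@@H]1CC[C@H]1[C@]2(C)CC[C@H](OC(=O)c3ccc(Cl)c(Cl)c3)C(C)(C)O[C@H]2CC[C@@]1(C)O`: 11900 nM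
- compound 3 `CC1=CC[C@H]2[C@H](CC[C@]2(C)O)C(C)(C)[C@@H]1CC[C@H]1[C@]2(C)CC[C@H](OC(=O)c3cccc(C(F)(F)F)c3)C(C)(C)O[C@H]2CC[C@@]1(C)O`: 37900 nM

Compound 3 cannot be separated from its pyridin-4-yl partner, given a 1.5-fold higher number from compound 1 to compound 3 (0.18 log units; within the scatter). Its gap to the dichlorinated member is clearer, at a 3.2-fold higher number from compound 2 to compound 3 (0.50 log units; beyond the scatter).

Compound 4 `CC1=CC[C@H]2[C@H](CC[C@]2(C)O)C(C)(C)[C@@H]1CC[C@H]1[C@]2(C)CC[C@H](OC(=O)c3ccccc3Cl)C(C)(C)O[C@H]2CC[C@@]1(C)O` differs from compound 3 by 2-chlorophenyl in place of 3-(trifluoromethyl)phenyl on a carbonyl carbon, with 2-chlorophenyl in place of 3-(trifluoromethyl)phenyl on a carbonyl carbon. Among the measured compounds shown here, no measured compound carries this group. For the measured compounds named here, the closest guide is compound 2, the only chlorinated member, with a 2.1-fold lower number from compound 1 to compound 2 (0.33 log units; beyond the scatter). All measured steps here are small, so only a small move towards a lower number is expected in this assay, perhaps none beyond the scatter. The expected step is a 1.7-fold lower number from compound 3 to compound 4 (0.24 log units; within the scatter). For compound 4 the estimated value is 22000 nM, with an expected range of 10000 nM to 45000 nM.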

Compound 4, half-maximal inhibitory concentration: 12100 nM
Compound 4: middle estimate off by 1.8-fold (0.26 log units), on the high side; the measured number falls inside the stated range.
By their numbers in this assay, from the lowest: compounds 2 and 4 (each within the scatter of the next); then compounds 1 and 3 (each within the scatter of the next).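

In this assay, the 2-chlorophenyl group on this carbonyl carbon stands apart from 3-(trifluoromethyl)phenyl, with a 3.1-fold lower number from compound 3 to compound 4 (0.50 log units; beyond the scatter), and from pyridin-4-yl, with a 2.1-fold lower number from compound 1 to compound 4 (0.32 log units; beyond the scatter). It cannot be told from 3,4-dichlorophenyl, with a 1.0-fold higher number from compound 2 to compound 4 (0.01 log units; within the scatter), so both chlorinated members now sit together, apart from compound 1 and compound 3. No supporting data bear on why this grouping appears.

On these data alone, whether it extends beyond chlorine remains open: an unsubstituted phenyl, a bromophenyl or an aminophenyl group would test this. The effect of replacing the aryl group with a longer alkyl chain is also unknown.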